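Removing the fluoro group from compound 3

The source may hold more compounds than are shown below. What is called first, only, known or untested is meant among the compounds shown, and "the series" means these compounds.

Measured in a functional assay on A-375 cells (Homo sapiens) for antiproliferative activity, read by MTT assay, with a stated time of 72 h; a higher number here means a weaker inhibitor, a lower number a stronger inhibitor:
Compound 1 `O=C1COc2ccc(-c3cnc4ccccc4c3)cc2N1C1CCCCC1`: > 40000 nM, a limit
Compound 2 `COc1ccc(N2C(=O)COc3ccc(-c4cnc5ccccc5c4)cc32)cc1`: > 40000 nM, a limit
Compound 3 `O=C1COc2ccc(-c3cnc4ccccc4c3)cc2N1c1ccc(F)cc1`: > 40000 nM, a limit

All three entries are limits rather than numbers. Compound 3 therefore has no readable potency: it stands at the limit of > 40000 nM in this assay, at which 3 of the 3 values shown sit, and no order among the three compounds can be given.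

Compound 4 `O=C1COc2ccc(-c3cnc4ccccc4c3)cc2N1c1ccccc1` differs from compound 3 by one change, (hydrogen in place of fluoro on an aromatic carbon). This is hydrogen in place of fluoro on an aromatic carbon, which turns 4-fluorophenyl into phenyl.

The closest measured change is a step that the two limits leave unreadable from compound 2 to compound 3, which also swaps a group on an aromatic carbon. Two others, a step that the two limits leave unreadable from compound 1 to compound 2 and a step that the two limits leave unreadable from compound 1 to compound 3, replace cyclohexyl on the amide-type nitrogen. None of these steps has a readable size, so no size can be carried over to the new change. Still, all three groups on that nitrogen left the compounds at the limit, so the expectation is no step beyond the scatter and another report of only a limit.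

The expected size of the change is a number no higher from compound 3 to compound 4 (the limit leaves the size open). For compound 4 the estimate is 40000 nM, with an expected range from 15000 nM to 80000 nM.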

Compound 4, half-maximal inhibitory concentration: > 40000 nM
Compound 4: no number, only a limit (the forecaster's own chance of this, stated with the estimate: 80%); the middle value lies on the limit itself.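

In this assay compound 4 is reported only as a limit, as are compounds 1, 2 and 3, so no step among these four compounds can be read. All four stand at the same reading: the limit of > 40000 nM in this assay, at which 4 of the 4 values shown sit.

The compounds shown leave open how potent each one actually is, and whether any group on the amide-type nitrogen of the shared core would give a measurable value in this assay.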